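Adding a Methyl to the Benzyl Ring of Compound 2

The source may report more compounds than this note shows. Statements on the series, on what has been measured and on what is new or still open speak of the compounds shown alone.

Of the compounds shown here, three sharing one core have been tested in a functional assay on SMMC-7721 cells (Homo sapiens) for antiproliferative activity, read by MTT assay, with a stated time of 72 h; a higher number here means a weaker inhibitor, a lower number a stronger inhibitor. Compound 1 `COc1cccc(CNCc2c(C(=O)O)n(Cc3ccc(C)cc3)c3cc(C)ccc23)c1` gives 3440 nM. Compound 2 `COc1cccc(CNCc2c(C(=O)O)n(Cc3ccccc3)c3cc(C(C)C)ccc23)c1` gives 3530 nM, and compound 3 `COc1ccc(Cn2c(C(=O)O)c(CNCc3cccc(O)c3)c3ccc(C(C)C)cc32)cc1` gives 5030 nM. Among these three numbers compound 2 holds the second highest, yet it sits within the usual scatter of both neighbours, so no order among them can be read from the data: compound 1 lies closest, compound 3 furthest, and neither gap is beyond the scatter.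

Compound 4 `COc1cccc(CNCc2c(C(=O)O)n(Cc3ccc(C)cc3)c3cc(C(C)C)ccc23)c1` has not yet been measured. It differs from compound 2 in one place: methyl in place of hydrogen on an aromatic carbon. Among the compounds with values here, no step between two measured compounds shows what such a change does on this core.

With nothing in the measured set to pull the number one way or the other, compound 4 is expected to land close to compound 2, with the step of a 1.1-fold lower number from compound 2 to compound 4 (0.03 log units; within the scatter) lying within the scatter. The estimate for compound 4 in this assay is 3300 nM, with a likely range from 1500 nM to 7500 nM.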

Compound 4, half-maximal inhibitory concentration: 2920 nM
Compound 4: middle estimate off by 1.1-fold (0.05 log units), on the high side; the range from low to high includes it.
By their numbers in this assay, from the lowest: compounds 4, 1, 2 and 3 (each within the scatter of the next).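

In this assay, within the data shown here, the change from benzyl to 4-methylbenzyl gives the first reading of this position on the shared core: a 1.2-fold lower number from compound 2 to compound 4 (0.08 log units; within the scatter) is a step within the scatter, so adding this methyl leaves no change that can be told from repeat-measurement noise. The isopropyl group now has a reading of its own as well, and a 1.2-fold lower number from compound 1 to compound 4 (0.07 log units; within the scatter) is also within the scatter, so on this evidence neither of these two single changes separates the compounds. Nothing in the available data bears on why these steps are so small. Still open, as far as these compounds go, is what a larger or differently built group at this place on the benzyl ring, such as an amine, a carboxylic acid or a longer chain, would do to the number. Whether any change here can move it beyond the scatter also remains unanswered.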